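A few compounds are considered here, and "the series" means these few. Any claim that something is new, unique, unknown or untested is made for them only; others in the source may bear on it.

Measured in a functional assay on BHK-21 cells (Mesocricetus auratus) for cytotoxicity, read by MTT assay; a higher number here means that more compound is tolerated, a lower number that less compound is tolerated:
- compound 1 `O=C(c1ccccc1)N1N=C(c2cccs2)CC1c1ccc(Cl)cc1`: > 300000 nM (a limit, not a number)
- compound 2 `CC(C)(C)C(=O)N1N=C(c2cccs2)CC1c1ccc(Cl)cc1`: 90000 nM
- compound 3 `O=C(c1ccccc1)N1N=C(c2cccs2)CC1c1ccc(F)cc1`: 100000 nM

Compound 1 stands at the limit of > 300000 nM in this assay, at which 1 of the 3 values shown sits. Any step away from it can therefore be read only against a limit.

Compound 4 `CC(C)(C)C1=NN(C(=O)c2ccccc2)C(c2ccc(Cl)cc2)C1` has not yet been measured. It differs from compound 1 as follows: tert-butyl in place of thiophen-2-yl on a carbon with a double bond to nitrogen. This puts tert-butyl in place of thiophen-2-yl on a carbon with a double bond to nitrogen.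

Going by the values given here, no measured step touches this place, so the evidence is indirect. The closest is an at least 3.3-fold lower number from compound 1 to compound 2 (0.52 log units; beyond the scatter), which also brings in tert-butyl, though in place of phenyl on a carbonyl carbon. The other is an at least 3.0-fold lower number from compound 1 to compound 3 (0.47 log units; beyond the scatter), with fluoro in place of chloro on an aromatic carbon. Both changes from compound 1 lead to lower numbers, and they are of similar size.

A step of comparable, modest size towards a lower number is therefore expected in this assay, with wide uncertainty. The expected change is an at least 2.3-fold lower number from compound 1 to compound 4 (0.36 log units; beyond the scatter). For compound 4 the estimated value is 130000 nM. The expected range for compound 4 runs from 50000 nM to 300000 nM.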

Compound 4, half-maximal cytotoxic concentration: 65000 nM
Compound 4: middle estimate off by 2.0-fold (0.30 log units), on the high side; the measured number falls inside the stated range.
By their numbers in this assay, from the lowest: compounds 4, 2 and 3 (each within the scatter of the next). At a limit, above all of these: compound 1.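

Going by these compounds alone, replacing thiophen-2-yl with tert-butyl on the carbon with a double bond to nitrogen gives an at least 4.6-fold lower number from compound 1 to compound 4 (0.66 log units; beyond the scatter) in this assay, so this position, which no earlier step touched, also bears on the read-out. Tert-butyl now lowers the number at two different places on the core of compound 1, since the change on the carbonyl carbon, in place of phenyl, gives an at least 3.3-fold lower number from compound 1 to compound 2 (0.52 log units; beyond the scatter). For compound 1 only a limit is available, so each of these steps fixes a minimum size and not a full size: the limit of > 300000 nM in this assay, at which 1 of the 4 values shown sits.

Still open, from the compounds shown here alone, is whether the lower number follows from losing thiophen-2-yl or from bringing in tert-butyl, and a phenyl, a furan-2-yl or a methyl group at this position would separate the two readings. Also open, going by these compounds, is whether the step at this position holds when fluoro stands in place of chloro on the aromatic carbon, or when a dimethylamino group is carried on the benzoyl ring.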